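Hydrogen for methyl on the terminal aryl group

This account rests on a few compounds, and the source may have more. Where it says the series, first, only, none or still open, it means among the compounds named here.

Measured in a functional assay on MCF7 cells (Homo sapiens) for cytotoxicity, read by MTT assay, with a stated time of 72 h; on this read-out higher numbers stand for weaker inhibition and lower numbers for stronger inhibition:
compound 1 `CNC(=O)c1cc(Oc2ccc(NC(=O)c3cc(-c4ccc(Cl)cc4)ncn3)cc2F)ccn1` gives > 100000 nM (a limit of the assay)
compound 2 `CNC(=O)c1cc(Oc2ccc(NC(=O)c3cc(-c4ccccc4)ncn3)cc2)ccn1` gives 18200 nM (a measured number)
compound 3 `CNC(=O)c1cc(Oc2ccc(NC(=O)c3cc(-c4ccc(C)cc4)ncn3)cc2F)ccn1` gives 19200 nM (a measured number)

Among the measured compounds shown here, compound 3 at 19200 nM lies within the scatter of compound 2 at 18200 nM and these are the only two measured numbers. The next change leads to compound 4 `CNC(=O)c1cc(Oc2ccc(NC(=O)c3cc(-c4ccccc4)ncn3)cc2F)ccn1` and is hydrogen in place of methyl on an aromatic carbon or, cut one bond further out, 4-methylphenyl to phenyl. For the measured compounds named here, one measured step bears on this place: methyl in place of chloro gave an at least 5.2-fold lower number from compound 1 to compound 3 (0.71 log units; beyond the scatter) and its size is open on one side. Phenyl itself occurs in compound 2 with 18200 nM as its value, which speaks against a large change. The expected result is a 1.0-fold higher number from compound 3 to compound 4 (0.02 log units; within the scatter) and no shift beyond the scatter is expected, though a drop to the limit of compound 1 cannot be excluded. Compound 4 is estimated at 20000 nM within an expected range from 8000 nM to 60000 nM in this series.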

Compound 4, half-maximal inhibitory concentration: 32400 nM
Compound 4: middle estimate off by 1.6-fold (0.21 log units), on the low side; the measured number falls inside the stated range.
By their numbers in this assay, from the lowest: compounds 2, 3 and 4 (each within the scatter of the next). At a limit, above all of these: compound 1.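

In this assay, hydrogen in place of methyl on this aromatic carbon stays within the scatter, a 1.7-fold higher number from compound 3 to compound 4 (0.23 log units; within the scatter), so the two groups are not told apart here. Fluoro in place of hydrogen on an aromatic carbon of the other ring is not resolved either, a 1.8-fold higher number from compound 2 to compound 4 (0.25 log units; within the scatter). Among the groups shown at the terminal aryl position, only chloro gives a step beyond the scatter, an at least 3.0-fold lower number from compound 1 to compound 4 (0.48 log units; beyond the scatter), and that step is open on one side: the limit of > 100000 nM in this assay, at which 1 of the 4 values shown sits.

On these data alone, with only hydrogen, methyl and chloro at this place, it remains open whether chloro stands alone or whether bromo, methoxy or an amine on the same carbon would read like it. Also open, as far as these compounds go, is how a carboxylic acid or a longer chain at this carbon would read.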